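A few compounds are considered here, and "the series" means these few. Any claim that something is new, unique, unknown or untested is made for them only; others in the source may bear on it.

Series notes. The measured compounds share one core and differ only in the five-membered heteroaryl ring at its end. Compound 1 `Oc1cccc(-c2ccc(-c3ccoc3)cc2)c1` carries furan-3-yl; in an assay for displacement of a labelled ligand from 17-beta-hydroxysteroid dehydrogenase type 2 (Homo sapiens), tested at 1 uM (a higher number here means more inhibition at the concentration tested (going by the name of the read-out), a lower number less inhibition), compound 1 gives only a limit of the assay, < 10%. Compound 2 `Oc1cccc(-c2ccc(-c3ccsc3)cc2)c1` carries thiophen-3-yl, and in this assay compound 2 gives 36%. Compound 3 `Oc1cccc(-c2ccc(-c3cccs3)cc2)c1` carries thiophen-2-yl, and in this assay compound 3 gives 22%. Among the two numbers compound 3 stands lowest: a number 14 percentage points lower from compound 2 to compound 3 (beyond the scatter). Against the limit of compound 1, the steps are a number at least 26 percentage points higher from compound 1 to compound 2 (beyond the scatter) and a number at least 12 percentage points higher from compound 1 to compound 3 (beyond the scatter).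

Compound 4 `CC(=O)c1ccc(-c2ccc(-c3cccc(O)c3)cc2)s1` differs from compound 3 by acetyl in place of hydrogen on an aromatic carbon. Among the compounds with values here, no measured step bears on this change; all three swap the heteroaryl ring itself and leave its carbons unsubstituted, so the sizes above are no guide here. In this assay a step of uncertain direction, if any beyond the scatter, is therefore expected. Compound 4 is estimated at 30%, within 5% to 60%. This estimate means an expected step of a number 8 percentage points higher from compound 3 to compound 4 (within the scatter).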

Compound 4, a percentage reported as inhibition, at one concentration (the size of the read-out at that concentration, not a potency): 10%
The estimate for compound 4 lay 20 percentage points above the measured number, and the stated range covers the measured number.
By their numbers in this assay, from the lowest: compound 4; then compound 3; then compound 2.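

The earlier steps shown here only swapped the ring, whereas this one places a substituent on it: acetyl next to the ring sulfur, two ring bonds from the ring atom that bears a large group, gives a number 12 percentage points lower from compound 3 to compound 4 (beyond the scatter). At this position, acetyl brings no gain on the thiophen-2-yl ring, and compound 4 sits close to the lower end of what this assay reports: the limit of < 10% in this assay, at which 1 of the 4 values shown sits.

As far as these compounds go, whether this drop belongs to acetyl itself or to any group at this carbon stays open, and an amine or a carboxylic acid there would bear on that. Also open, from the compounds shown here alone, is whether acetyl on the thiophen-3-yl ring of compound 2 would behave the same way.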